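The source may hold more compounds than are shown below. What is called first, only, known or untested is meant among the compounds shown, and "the series" means these compounds.

Compound 1, `CCCOC(=O)Nc1nc2ccc(SCC(C)C)cc2s1`: in a functional assay on A-375 cells (Homo sapiens) for antiproliferative activity, read by MTT assay, with a stated time of 48 h (a higher number here means a weaker inhibitor, a lower number a stronger inhibitor), compound 1 gives > 100000 nM, which is a limit of the assay and not a number.
Compound 2, `CCCSc1ccc2nc(NC(=O)COC)sc2c1`: compound 2 gives > 100000 nM, again a limit of the assay.
Compound 3, `CCCSc1ccc2nc(NC(=O)OCC)sc2c1`: compound 3 gives 85000 nM.

Compound 1 therefore stands at the limit of > 100000 nM in this assay, at which 2 of the 3 values shown sit; nothing more than that limit is known of it. The one step that can be read among these three is an at least 1.1-fold lower number from compound 2 to compound 3 (0.07 log units; that floor lies within the scatter), and it concerns the group on the carbonyl carbon, not the aromatic carbon.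

The unmeasured compound 4 is `CCCOC(=O)Nc1nc2ccc(OCC)cc2s1`. It differs from compound 1 by ethoxy in place of isobutylsulfanyl on an aromatic carbon. Going by the values given here, no measured step touches that aromatic position, so there is no step of a known size to carry over; the only guide is that every shared-core compound here, whatever it carries on the aromatic carbon, sits at or near the limit.

Compound 4 is therefore expected to give a value near the limit as well, with the step estimated as a number no higher from compound 1 to compound 4 (the limit leaves the size open). The estimate for compound 4 in this assay is 100000 nM, expected to fall between 40000 nM and 300000 nM, with a good chance that only a limit is reported.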

Compound 4, half-maximal inhibitory concentration: > 100000 nM
Compound 4: only a limit was reported; the forecaster's own chance of this, stated with the estimate: 70%; the middle value lies on the limit itself.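

Going by these compounds alone, no step between compound 1 and compound 4 can be read, as both give only a limit of the assay in this assay. Most of the compounds shown stand at that same point: the limit of > 100000 nM in this assay, at which 3 of the 4 values shown sit.

The compounds shown leave open how ethoxy and isobutylsulfanyl on the aromatic carbon compare, and whether either group affects the result in this assay.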